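This account rests on a few compounds, and the source may have more. Where it says the series, first, only, none or still open, it means among the compounds named here.

Of the compounds shown here, three sharing one core have been measured in an assay on LtK cells with ATP-sensitive inward rectifier potassium channel 11 (Homo sapiens) as the target; a lower number here means that less compound is needed, a higher number that more compound is needed for the effect. Compound 1 `O=C(Nc1c(C(O)(C(F)(F)F)C(F)(F)F)ccc2ccccc12)C1CC1`, carrying a cyclopropyl on the carbonyl carbon, gives 751 nM. Compound 2 `O=C(Nc1c(C(O)(C(F)(F)F)C(F)(F)F)ccc2ccccc12)c1cccc(Br)c1` gives 80 nM, and compound 3 `O=C(Nc1c(C(O)(C(F)(F)F)C(F)(F)F)ccc2ccccc12)c1ccc(Cl)cc1` gives 570 nM. Among these three numbers compound 3 stands second highest: its value and that of compound 1 lie within the usual scatter of each other, while a 7.1-fold higher number from compound 2 to compound 3 (0.85 log units; beyond the scatter) is a step beyond it. The exchange a 9.4-fold lower number from compound 1 to compound 2 (0.97 log units; beyond the scatter) is the other step beyond the scatter; a 1.3-fold lower number from compound 1 to compound 3 (0.12 log units; within the scatter) is not.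

Compound 4 `COc1ccc(C(=O)Nc2c(C(O)(C(F)(F)F)C(F)(F)F)ccc3ccccc23)cc1` is reached from compound 3 by a single change: methoxy in place of chloro on an aromatic carbon. Among the compounds with values here, none of the measured steps swaps one group for another on the same aromatic carbon of the phenyl ring, so nothing measured speaks directly to this exchange; the measured steps only show that what sits on the carbonyl carbon can move the number by a modest amount. Within the data shown here, with no direct precedent, the expectation for compound 4 is a step of no clear direction, a 1.3-fold lower number from compound 3 to compound 4 (0.10 log units; within the scatter), and its value in this assay is estimated at 450 nM, within a range from 150 nM to 1400 nM.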

Compound 4, half-maximal effective concentration: 417 nM
Compound 4: the middle estimate sits 1.1-fold (0.03 log units) above what was measured; the range from low to high includes it.
By their numbers in this assay, from the lowest: compound 2; then compounds 4, 3 and 1 (each within the scatter of the next).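

Within the data shown here, exchanging the chloro of compound 3 for methoxy on the same aromatic carbon, para to a large group, gives the first direct reading at this position: in this assay the step is a 1.4-fold lower number from compound 3 to compound 4 (0.14 log units; within the scatter) and the two groups cannot be told apart. The 4-methoxyphenyl also cannot be told apart from the cyclopropyl, with a 1.8-fold lower number from compound 1 to compound 4 (0.26 log units; within the scatter) on the carbonyl carbon. The 3-bromophenyl remains separate, with a 5.2-fold higher number from compound 2 to compound 4 (0.72 log units; beyond the scatter), so compound 2 still has the lowest number of the four, and no measurement on hand accounts for this.

The compounds shown do not separate the effect of the bromine itself from that of its place in the 3-bromophenyl of compound 2. Going by these compounds, how an amine or a carboxylic acid in place of the methoxy would read in this assay also stays open.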